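Ester Side-Chain Variation in a Dihydropyridine Calcium Channel Series

The compounds below may be only part of what the source reports. "The series", "measured", "known", "first", "only" and "open" are said of these compounds alone.

Compounds measured so far:
- compound 1, `COC(=O)C1=C(C)NC(C)=C(C(=O)OCCCl)C1c1cccc([N+](=O)[O-])c1`: 26 nM
- compound 2, `COC(=O)C1=C(C)NC(C)=C(C(=O)OCc2ccco2)C1c1cccc([N+](=O)[O-])c1`: 20 nM
- compound 3, `COC(=O)C1=C(C)NC(C)=C(C(=O)OCCCCc2ccccc2)C1c1cccc([N+](=O)[O-])c1`: 10 nM

All three share one core and differ only in the ester side chain. In a functional assay on HEK293 cells for antagonist activity at Voltage-dependent L-type calcium channel subunit alpha-1C (Oryctolagus cuniculus), read by FLIPR (on this read-out higher numbers stand for weaker inhibition and lower numbers for stronger inhibition), compound 3 gives the lowest number of the three, though one of its two steps, a 2.0-fold lower number from compound 2 to compound 3 (0.30 log units; within the scatter), is within the scatter, while the other, a 2.6-fold lower number from compound 1 to compound 3 (0.41 log units; beyond the scatter), is beyond it.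

Compound 4, `COC(=O)C1=C(C)NC(C)=C(C(=O)OCCOCc2ccccc2)C1c1cccc([N+](=O)[O-])c1`, is not yet measured. It differs from compound 3 by benzyloxy in place of phenethyl on a saturated chain carbon, two bonds along the chain from an oxygen next to a carbonyl group. The step from compound 1 to compound 3 shows that introducing an aromatic ring on this chain gives a modest lowering, and the step from compound 2 to compound 3 shows that swapping one ring-bearing chain for another stays within the scatter. Compound 4 keeps an aromatic ring on a chain of similar length, so the expected step of a 1.5-fold higher number from compound 3 to compound 4 (0.18 log units; within the scatter) is none beyond the scatter in this assay. Compound 4 is therefore estimated at 15 nM, with a range from 6 nM to 40 nM.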

Compound 4, half-maximal inhibitory concentration: 9 nM
Estimate against measurement, compound 4: 1.7-fold (0.22 log units) above; the measured number falls inside the stated range.
By their numbers in this assay, from the lowest: compounds 4, 3, 2 and 1 (each within the scatter of the next, the first and the last beyond it).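

In this assay, benzyloxy in place of phenethyl brings an oxygen into the chain and adds a hydrogen-bond acceptor while keeping the same count of heavy atoms, yet the two compounds cannot be told apart: a 1.1-fold lower number from compound 3 to compound 4 (0.05 log units; within the scatter). So at this place on the ester side chain, this swap of a chain carbon for an oxygen leaves no mark that the read-out can resolve, and compound 4 stands clear of both other side chains, with a 2.2-fold lower number from compound 2 to compound 4 (0.35 log units; beyond the scatter) and a 2.9-fold lower number from compound 1 to compound 4 (0.46 log units; beyond the scatter). Nothing given here accounts for this result.

As far as these compounds go, it remains open whether an amine in that same chain, in place of the oxygen, would be accepted as well. From the compounds shown here alone, it is also open whether a longer chain, or a cyclohexyl ring in place of the phenyl ring, would hold these numbers.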